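The compounds below may be only part of what the source reports. "The series", "measured", "known", "first", "only" and "open" are said of these compounds alone.

Measured so far:
- compound 1 `N#Cc1ccc(NC(=O)c2ccc(-c3ncccc3C(F)(F)F)cc2)cc1`: 417 nM
- compound 2 `Cc1cccnc1-c1ccc(C(=O)Nc2ccc(Cl)cc2)cc1`: 1500 nM
- compound 3 `CC(C)(C)c1ccc(NC(=O)c2ccc(-c3ccccn3)cc2)cc1`: 11 nM

In a functional assay for antagonist activity at transient receptor potential cation channel subfamily V member 1 (Homo sapiens), read by FLIPR (on this read-out higher numbers stand for weaker inhibition and lower numbers for stronger inhibition), compound 3 gives 11 nM, the lowest number of the three. Compound 1 stands nearest with 417 nM, and compound 2 furthest with 1500 nM; both of these gaps lie beyond the scatter, so compound 3 is the strongest inhibitor of the set. For the measured compounds named here, compounds 1 and 2 differ from compound 3 in more than one place, so no single step between any pair of measured compounds can be read off.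

The unmeasured compound 4 `CC(C)(C)c1ccc(NC(=O)c2ccc(-c3ncccc3N(S(C)(=O)=O)S(C)(=O)=O)cc2)cc1` is reached from compound 3 by one change: bis(methylsulfonyl)amino in place of hydrogen on an aromatic carbon. Going by the values given here, no measured pair isolates such a change, so the expectation rests on the three numbers alone. Compound 1 and compound 2 each carry a group ortho to the large group on the same kind of ring and each gives a higher number than compound 3, but other parts also differ, so this is only a hint. Compound 4 is expected to show a step toward weaker inhibition of a 14-fold higher number from compound 3 to compound 4 (1.13 log units; beyond the scatter), beyond the scatter. In this assay compound 4 is estimated at 150 nM, within a range from 30 nM to 800 nM.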

Compound 4, half-maximal inhibitory concentration: 0.8 nM
Compound 4: the middle estimate sits 190-fold (2.27 log units) above what was measured; measured number outside the range, below it.
By their numbers in this assay, from the lowest: compound 4; then compound 3; then compound 1; then compound 2.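

In this assay, the place on the six-membered aromatic ring with 1 nitrogen, ortho to a large group and two atoms from the ring nitrogen, accepts bis(methylsulfonyl)amino, a group of 9 heavy atoms, and the swap for hydrogen gives a 14-fold lower number from compound 3 to compound 4 (1.14 log units; beyond the scatter). For the compounds shown here, no earlier pair isolated any change at this place, so this is the first single-change reading there, and it links this substituent with stronger inhibition rather than weaker. No measurement shown here bears on why the number falls.

The compounds shown leave open whether the step needs both methylsulfonyl arms, since no single step is given for a lone methylsulfonylamino group, a plain amine or a small alkoxy group such as methoxy at this place. They also leave open whether the same change would give a step of similar size on a compound that carries something other than the group on the far ring of compound 3, such as a nitrile or a chlorine atom.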